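Guanidine H1 antagonists: swapping cyclohexyl for phenyl

The source may hold more compounds than are shown below. What is called first, only, known or untested is meant among the compounds shown, and "the series" means these compounds.

Compound 1 `CN/C(=N\CCCC(c1ccc(Cl)c(Cl)c1)c1ccccn1)NCCCc1c[nH]cn1`: 6.16
Compound 2 `Clc1ccc(C(CCC/N=C(/NCCCc2c[nH]cn2)NC2CCCCC2)c2ccccn2)cc1Cl`: 5.76

In a functional assay on ileum for antagonist activity at histamine H1 receptor (Cavia porcellus) (on this read-out higher numbers stand for higher potency (the scale is a negative logarithm) and lower numbers for lower potency), compound 2 gives the lower of the two numbers; its nearest neighbour, compound 1, sits higher by a number 0.40 log units lower from compound 1 to compound 2 (beyond the scatter). The unmeasured compound 3 `Clc1ccc(C(CCC/N=C(/NCCCc2c[nH]cn2)Nc2ccccc2)c2ccccn2)cc1Cl` differs from compound 2 by phenyl in place of cyclohexyl on an amine nitrogen. For the measured compounds named here, no measured step matches this exchange; the only step known on this nitrogen is a number 0.40 log units lower from compound 1 to compound 2 (beyond the scatter), which was modest. Compound 3 is therefore expected to stay near compound 2, with an estimated step of a number 0.14 log units higher from compound 2 to compound 3 (within the scatter) within the scatter. The estimate for compound 3 in this assay is 5.9, between 5.4 and 6.4.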

Compound 3, negative logarithm of the antagonist equilibrium constant: 5.5
Estimate against measurement, compound 3: 0.40 log units above; low and high end bracket the measured number.
By their numbers in this assay, from the lowest: compounds 3 and 2 (each within the scatter of the next); then compound 1.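

Putting phenyl where cyclohexyl stood on this amine nitrogen gives a number 0.26 log units lower from compound 2 to compound 3 (within the scatter) in this assay, so this read-out does not separate the aromatic ring from the non-aromatic one. Set against the methyl of compound 1, phenyl gives a number 0.66 log units lower from compound 1 to compound 3 (beyond the scatter) and cyclohexyl gives a number 0.40 log units lower from compound 1 to compound 2 (beyond the scatter), so both six-membered rings read lower than methyl. Nothing available explains these numbers. The compounds shown leave open how an ethyl group or a benzyl group would fare on this nitrogen, and whether a hydroxyl or a methoxy group on the phenyl ring would shift the number.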